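Phenyl to pyridin-2-yl in a benzyloxy side chain

This account rests on a few compounds, and the source may have more. Where it says the series, first, only, none or still open, it means among the compounds named here.

The series shares one core with varied substituents. Compound 1 `Cc1nc2ccc(NC(=O)COc3ccc(OC(F)(F)F)cc3)cn2c1C` gives 3.8 nM in an assay on CHO cells for displacement of a labelled ligand from melanin-concentrating hormone receptor 1 (Homo sapiens), read by scintillation counting, with a stated time of 1 h; a higher number here means a weaker inhibitor, a lower number a stronger inhibitor. Compound 2 `Cc1c(C2CC2)nc2ccc(-n3ccc(OCc4ccccc4)cc3=O)cn12` gives 42 nM in this assay, and compound 3 `CCc1nc2ccc(-n3ccc(OCc4ccccc4)cc3=O)cn2c1C` gives 120 nM in this assay. Compound 2 thus holds the second highest of the three numbers: its nearest neighbour is compound 3, with a 2.9-fold higher number from compound 2 to compound 3 (0.46 log units; beyond the scatter) for ethyl in place of cyclopropyl on an aromatic carbon, while compound 1 is furthest, its value standing well below that of compound 2.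

Compound 4 `Cc1c(C2CC2)nc2ccc(-n3ccc(OCc4ccccn4)cc3=O)cn12` differs from compound 2 by pyridin-2-yl in place of phenyl on a saturated chain carbon bound to an oxygen on an aromatic ring. Within the data shown here, no measured step in this set touches the benzyloxy group; the only step known, from cyclopropyl to ethyl, concerns another part of the molecule and offers no direct guide. With nothing to point in either direction, a change within the scatter, or a small shift at most, is the plain expectation. Compound 4 is therefore estimated at 60 nM in this assay, within 20 nM to 180 nM, meaning an expected step of a 1.4-fold higher number from compound 2 to compound 4 (0.15 log units; within the scatter).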

Compound 4, half-maximal inhibitory concentration: 240 nM
Compound 4: middle estimate off by 4.0-fold (0.60 log units), on the low side, and the stated range ends below it.
By their numbers in this assay, from the lowest: compound 1; then compound 2; then compounds 3 and 4 (each within the scatter of the next).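

In this assay, the benzyloxy side chain proves sensitive to a change within its ring: pyridin-2-yl in place of phenyl gives a 5.7-fold higher number from compound 2 to compound 4 (0.76 log units; beyond the scatter), although both groups count 6 heavy atoms and the entering group adds a ring nitrogen and 1 hydrogen-bond acceptor. Among these compounds, the earlier step concerned only cyclopropyl and ethyl on an aromatic carbon, so this is the first reading at the side chain itself, and here the change raises the number. Nothing at hand bears on the reason for this shift.

Going by these compounds, it remains open how pyridin-3-yl, pyridin-4-yl or a fluorophenyl group would read on this saturated chain carbon. Also open, on these data alone, is whether pyridin-2-yl would produce a similar step in a compound carrying ethyl in place of cyclopropyl.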